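The source may report more compounds than this note shows. Statements on the series, on what has been measured and on what is new or still open speak of the compounds shown alone.

Measured so far:
- compound 1 `CCCc1ccc(N2C(=O)NC3(CSC4=C3C(=O)c3ncccc3C4=O)C2=O)cc1`: 1 nM
- compound 2 `CCCCCc1ccc(N2C(=O)NC3(CSC4=C3C(=O)c3ncccc3C4=O)C2=O)cc1`: 250 nM

In a functional assay on HT-29 cells (Homo sapiens) for antiproliferative activity, read by MTT assay, with a stated time of 96 h (on this read-out lower numbers stand for stronger inhibition and higher numbers for weaker inhibition), compound 1 gives 1 nM and compound 2 gives 250 nM. Among the measured compounds shown here, compound 2 thus stands highest of the two numbers, and the only known step is a 250-fold higher number from compound 1 to compound 2 (2.40 log units; beyond the scatter). Compound 3 `CN(C)c1ccc(N2C(=O)NC3(CSC4=C3C(=O)c3ncccc3C4=O)C2=O)cc1` is unmeasured; it differs from compound 2 by dimethylamino in place of pentyl on an aromatic carbon. For the measured compounds named here, no measured step exchanges a chain for a nitrogen-bearing group on this aromatic carbon, so the one step that bears on the move is a 250-fold higher number from compound 1 to compound 2 (2.40 log units; beyond the scatter), which shows a longer chain carrying a far higher number than propyl. The dimethylamino entering in compound 3 is smaller than the pentyl it replaces and nearer in size to the propyl of compound 1. Compound 3 is therefore expected to give a step of a 25-fold lower number from compound 2 to compound 3 (1.40 log units; beyond the scatter) in this assay, toward a lower number, though the change of group type leaves the size uncertain. Compound 3 is estimated at 10 nM, with a range of 1 nM to 120 nM.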

Compound 3, half-maximal inhibitory concentration: 20 nM
Compound 3: middle estimate off by 2.0-fold (0.30 log units), on the low side; low and high end bracket the measured number.
By their numbers in this assay, from the lowest: compound 1; then compound 3; then compound 2.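

In this assay, this aromatic carbon tolerates a nitrogen-bearing group as well as a plain chain: dimethylamino in place of pentyl gives a 13-fold lower number from compound 2 to compound 3 (1.10 log units; beyond the scatter), so the high number of compound 2 is not a fixed feature of the shared core. The same group does not match propyl, with a 20-fold higher number from compound 1 to compound 3 (1.30 log units; beyond the scatter), which places dimethylamino between the two chains and shows that the number at this position is not set by the chain alone. Nothing measured here accounts for either step.

Still open, from the compounds shown here alone, is how the number runs between propyl and pentyl, as with butyl, and whether a shorter chain such as ethyl stays as low as compound 1. Also open, going by these compounds, is whether the nitrogen itself matters, which diethylamino or methoxy on this carbon would test.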